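An aryl exchange on a shared core, and its expected outcome

The compounds below may be only part of what the source reports. "The series", "measured", "known", "first", "only" and "open" are said of these compounds alone.

Compound 1 `C[C@@H]1CN(c2sc(C(F)(F)F)nc2-c2nc3ccccc3[nH]2)CCN1C(=O)Cn1cnc2cccnc21`: 1.6 nM
Compound 2 `Cc1nc(C)n(CC(=O)N2CCN(c3sc(C(F)(F)F)nc3-c3cnc(OC(C)C)nc3)C[C@H]2C)n1`: 3.4 nM

Of the compounds shown here, two have so far been measured in a functional assay on CHO-K1 cells for antagonist activity at C-X-C chemokine receptor type 3 (Homo sapiens), read by FLIPR, with a stated time of 10 min; a lower number here means a stronger inhibitor, a higher number a weaker inhibitor. Compound 2 has the higher of the two numbers; its nearest neighbour, compound 1, lies below it by a margin that is beyond the usual scatter. Compound 3 `CCOc1ccc(-c2nc(C(F)(F)F)sc2N2CCN(C(=O)Cn3nc(C)nc3C)[C@H](C)C2)cn1` has not yet been measured. It differs from compound 2 in one place: 6-ethoxypyridin-3-yl in place of 2-isopropoxypyrimidin-5-yl on an aromatic carbon. Within the data shown here, no pair of measured compounds isolates this change, so nothing in the data tells how such an exchange of one six-membered aromatic ring for another moves the number. The step is therefore expected to be small, a 1.2-fold higher number from compound 2 to compound 3 (0.07 log units; within the scatter), with no direction that can be told apart from the scatter. Compound 3 is estimated at 4 nM in this assay, within a range from 1.5 nM to 12 nM.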

Compound 3, half-maximal inhibitory concentration: 8.8 nM
Beside the measured number, compound 3's estimate is 2.2-fold (0.34 log units) below it; low and high end bracket the measured number.
By their numbers in this assay, from the lowest: compound 1; then compound 2; then compound 3.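

In this assay, a 2.6-fold higher number from compound 2 to compound 3 (0.41 log units; beyond the scatter) shows that this position, on an aromatic carbon of the five-membered ring and next to the ring nitrogen, does respond to an exchange of one six-membered aromatic ring for another, with a modest step beyond the scatter. The exchange alters two things at once, the hetero atoms of the ring and the chain on its oxygen, which goes from isopropoxy to ethoxy, so this single step cannot divide its size between them. Nothing available accounts for the step.

The compounds shown leave open how much of the step belongs to the ring and how much to the chain, a question that a 6-isopropoxypyridin-3-yl group would address. Also open, from the compounds shown here alone, is how the number would move if an amine replaced the ether oxygen on this ring.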